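Sulfonyl variations on a piperidine ester core

The compounds below may be only part of what the source reports. "The series", "measured", "known", "first", "only" and "open" are said of these compounds alone.

Measured so far:
compound 1 `CC(C)c1noc(N2CCN(C(=O)[C@@H]3CCCN(S(=O)(=O)c4ccc(S(=O)(=O)C(C)C)cc4)C3)CC2)n1` gives 70 nM in a functional assay on MIA PaCa-2 cells (Homo sapiens) for inhibition, read by MTT assay, with a stated time of 7 days; a lower number here means a stronger inhibitor, a higher number a weaker inhibitor
compound 2 `CCOC(=O)[C@@H]1CCCN(S(=O)(=O)c2ccc(S(=N)(=O)N(CC)CC)cc2)C1` gives 2600 nM in this assay
compound 3 `CC(C)c1noc(N2CCN(C(=O)[C@@H]3CCCN(S(=O)(=O)c4ccc(S(=O)(=O)NC5CC5)cc4)C3)CC2)n1` gives 1000 nM in this assay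

Compound 2 stands highest of the three numbers in this assay; its nearest neighbour is compound 3, its furthest compound 1. Compound 4 `CCOC(=O)[C@@H]1CCCN(S(=O)(=O)c2ccc(S(=O)(=O)N(C)C)cc2)C1` differs from compound 2 as follows: a group of 6 heavy atoms (2 carbon, 1 nitrogen, 2 oxygen, 1 sulfur; no ring) in place of a group of 8 heavy atoms (4 carbon, 2 nitrogen, 1 oxygen, 1 sulfur; no ring), on an aromatic carbon. Among the measured compounds shown here, no measured pair makes this exact exchange. For the measured compounds named here, the only step at the same place, a 14-fold higher number from compound 1 to compound 3 (1.15 log units; beyond the scatter), exchanged a group on the sulfonyl sulfur in a different core and moved the number strongly upward, so the site is sensitive; that step, however, does not transfer directly here. With one step of uncertain bearing, the expected change from compound 2 to compound 4 is modest, a 1.3-fold lower number from compound 2 to compound 4 (0.11 log units; within the scatter). Compound 4 is therefore expected to give about 2000 nM, with a range from 600 nM to 7000 nM.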

Compound 4, half-maximal inhibitory concentration: 900 nM
Compound 4: middle estimate off by 2.2-fold (0.35 log units), on the high side; the measured number falls inside the stated range.
By their numbers in this assay, from the lowest: compound 1; then compounds 4 and 3 (each within the scatter of the next); then compound 2.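

In this assay the exchange of the eight-heavy-atom group for dimethylsulfamoyl gives a 2.9-fold lower number from compound 2 to compound 4 (0.46 log units; beyond the scatter) and so lies beyond the scatter. This position on the aromatic ring therefore also responds to change in the ethyl ester core, not only in the core of compound 1, although this step is smaller than a 14-fold higher number from compound 1 to compound 3 (1.15 log units; beyond the scatter) in that other core. No measurement available here accounts for the step.

From the compounds shown here alone, whether dimethylsulfamoyl gives a similar result in the core of compound 1 remains open. So does the outcome with a primary sulfonamide or diethylsulfamoyl on the ester core.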